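This account rests on a few compounds, and the source may have more. Where it says the series, first, only, none or still open, it means among the compounds named here.

Measured so far in a physicochemical assay for acid dissociation, each entry a limit and not a number:

- Compound 1 `O=C1C(Cl)=C(Nc2ccc(S(=O)(=O)Nc3nccs3)cc2)C(=O)c2ccccc21`: < 7.91
- Compound 2 `Cc1cc(C)nc(NS(=O)(=O)c2ccc(NC3=C(Cl)C(=O)c4ccccc4C3=O)cc2)n1`: < 7.91
- Compound 3 `Cc1noc(NS(=O)(=O)c2ccc(NC3=C(Cl)C(=O)c4ccccc4C3=O)cc2)c1C`: < 7.91

Compound 3 is known only through a limit, < 7.91. The series shares this position, with the limit of < 7.91 in this assay, at which 3 of the 3 values shown sit.

Compound 4 `Cc1nnc(NS(=O)(=O)c2ccc(NC3=C(Cl)C(=O)c4ccccc4C3=O)cc2)s1` carries 5-methyl-1,3,4-thiadiazol-2-yl in place of 3,4-dimethyl-1,2-oxazol-5-yl on a sulfonamide nitrogen.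

The measured steps that bear on this change are a step that the two limits leave unreadable from compound 1 to compound 3 and a step that the two limits leave unreadable from compound 2 to compound 3. Neither offers a size or a direction to carry over, so no step beyond the scatter is expected in this assay. The expected change is a step that the limit leaves unreadable from compound 3 to compound 4. For compound 4 the estimate is 7.2, with an expected range from 6 to 7.9.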

Compound 4, acid dissociation constant: < 7.91
Compound 4 gave a limit, no number; the forecaster's own chance of this, stated with the estimate: 60%; the middle value is on the limit's open side.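

In this assay, among the compounds shown here, compound 4 gives only a limit, as do compound 1, compound 2 and compound 3, so no step among them can be read: the limit of < 7.91 in this assay, at which 4 of the 4 values shown sit. The compounds shown leave open whether changing the group on the sulfonamide nitrogen shifts the acid dissociation constant at all.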